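A few compounds are considered here, and "the series" means these few. Any claim that something is new, unique, unknown or untested is made for them only; others in the source may bear on it.

Measured so far:
- compound 1 `CCC(CC)N1CCN(c2nc3c(c(Nc4ccc(C(F)(F)F)cc4)n2)CCN(c2ncccc2C(F)(F)F)CC3)CC1`: 243 ug/mL
- compound 2 `CN(c1nc2c(c(Nc3ccc(C(F)(F)F)cc3)n1)CCN(c1ncccc1C(F)(F)F)CC2)C1CCCNC1`: > 241 ug/mL, a limit
- compound 3 `FC(F)(F)c1ccc(Nc2nc(N3CCN(C4CCC4)CC3)nc3c2CCN(c2ncccc2C(F)(F)F)CC3)cc1`: > 237 ug/mL, a limit

All three results come from a physicochemical assay for solubility, in phosphate buffer, measured as thermodynamic solubility, at pH 2; a higher number here means a more soluble compound, a lower number a less soluble compound. Compound 3 stands at a limit of > 237 ug/mL, not at an exact number.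

The next compound is compound 4 `FC(F)(F)c1ccc(Nc2nc(NC3CCCNC3)nc3c2CCN(c2ncccc2C(F)(F)F)CC3)cc1`. In it, (piperidin-3-yl)amino takes the place of 4-cyclobutylpiperazin-1-yl on an aromatic carbon: (piperidin-3-yl)amino in place of 4-cyclobutylpiperazin-1-yl on an aromatic carbon.

Among the measured compounds shown here, three measured steps bear on this change: a step that the limit leaves unreadable from compound 1 to compound 2, a step that the limit leaves unreadable from compound 1 to compound 3 and a step that the two limits leave unreadable from compound 2 to compound 3. The last is the closest guide, since methyl(piperidin-3-yl)amino is the nearest match to the entering group. None of the three has a readable size, so they give no direction and no reason to expect a change beyond the scatter. For the measured compounds named here, the only exact number is for compound 1, at 243 ug/mL, and it anchors the expectation. The expected change is a step that the limit leaves unreadable from compound 3 to compound 4. Compound 4 is expected to give about 240 ug/mL, with an estimated range of 130 ug/mL to 400 ug/mL.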

Compound 4, solubility: > 235 ug/mL
Compound 4: only a limit was reported (the forecaster's own chance of this, stated with the estimate: 70%); the middle value does not contradict the limit.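

Compound 4 is reported only as a limit, so its steps to compound 1, compound 2 and compound 3 cannot be read. The compounds shown leave open what exact values compound 2, compound 3 and compound 4 would give in this assay, and so whether swapping these groups changes the read-out at all.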